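Acyl chain extension on the anilide, second step

This account rests on a few compounds, and the source may have more. Where it says the series, first, only, none or still open, it means among the compounds named here.

Compound 1 `CC(=O)Nc1ccc(S(=O)(=O)Oc2ccccc2C(C)C)cc1` and compound 2 `CCC(=O)Nc1ccc(S(=O)(=O)Oc2ccccc2C(C)C)cc1` share one core and differ only in the acyl chain of the anilide. In a functional assay on MCF7 cells (Homo sapiens) for antiproliferative activity, read by sulforhodamine B assay, with a stated time of 48 h (on this read-out lower numbers stand for stronger inhibition and higher numbers for weaker inhibition), compound 1 gives 16000 nM, and compound 2 gives 11000 nM. The step between them, a 1.5-fold lower number from compound 1 to compound 2 (0.16 log units; within the scatter), is small. Of the two numbers shown, compound 2 carries the smaller one, but the gap to compound 1 is within the scatter, so the two compounds are not separated on this read-out.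

Compound 3 `CCCC(=O)Nc1ccc(S(=O)(=O)Oc2ccccc2C(C)C)cc1` has not yet been measured. It differs from compound 2 by methyl in place of hydrogen on a saturated chain carbon, two bonds along the chain from a carbonyl carbon. Among the measured compounds shown here, the only measured step that bears on this change is a 1.5-fold lower number from compound 1 to compound 2 (0.16 log units; within the scatter), the same kind of one-carbon lengthening of the acyl chain, one bond closer to the carbonyl. With that step within the scatter, no change beyond the scatter is expected for the next lengthening either; at most a slight drift toward a lower number.

For compound 3 the expected value in this assay is 9000 nM. The expected range for compound 3 runs from 4000 nM to 20000 nM. The step this estimate implies, a 1.2-fold lower number from compound 2 to compound 3 (0.09 log units; within the scatter), is expected to remain within the scatter.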

Compound 3, half-maximal inhibitory concentration: 6600 nM
Compound 3: middle estimate off by 1.4-fold (0.13 log units), on the high side, and the stated range covers the measured number.
By their numbers in this assay, from the lowest: compounds 3, 2 and 1 (each within the scatter of the next, the first and the last beyond it).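

In this assay, methyl in place of hydrogen on a saturated chain carbon, two bonds along the chain from a carbonyl carbon, gives a 1.7-fold lower number from compound 2 to compound 3 (0.22 log units; within the scatter) and so does not by itself separate compound 3 from compound 2. Taken as one change, the whole lengthening of the acyl chain gives a 2.4-fold lower number from compound 1 to compound 3 (0.38 log units; beyond the scatter) and is the first gap in this short series to clear the scatter, though only modestly. The acyl chain therefore has a measurable, small influence on this read-out that neither single step shows on its own, and nothing available bears on why this is so.

From the compounds shown here alone, whether the trend from compound 1 to compound 3 continues with a longer chain such as butyl or pentyl, or stops or reverses, remains open. Also open, going by these compounds, is how this assay responds to a branched chain or to a chain ending in an amine or a carboxylic acid at this position.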